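This account rests on a few compounds, and the source may have more. Where it says the series, first, only, none or still open, it means among the compounds named here.

Of the compounds shown here, two have been measured in an assay on membranes from Cortex for displacement of a labelled ligand from Sigma non-opioid intracellular receptor 1 (Cavia porcellus), read by scintillation counting, with a stated time of 120 min; a lower number here means a stronger inhibitor, a higher number a weaker inhibitor. Compound 1 `O=C(c1ccc(F)cc1)N1CCC(NCC[S+]([O-])C(c2ccc(F)cc2)c2ccc(F)cc2)CC1` gives 1440 nM in this assay. Going by the values given here, compound 2 `CC(C)(C)C(=O)N1CCC(NCC[S+]([O-])C(c2ccc(F)cc2)c2ccc(F)cc2)CC1` gives 11200 nM in this assay, the highest of the two numbers; its nearest neighbour is compound 1, and the single step between them, a 7.8-fold higher number from compound 1 to compound 2 (0.89 log units; beyond the scatter), stands beyond the scatter. No other pairs are available.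

Compound 3 `O=C(c1ccccc1F)N1CCC(NCC[S+]([O-])C(c2ccc(F)cc2)c2ccc(F)cc2)CC1` has not been measured. It differs from compound 2 in one place: 2-fluorophenyl in place of tert-butyl on a carbonyl carbon. Among the compounds with values here, this change brings an aromatic ring back onto the carbonyl carbon where compound 2 carries tert-butyl, so the only step that bears on it is a 7.8-fold higher number from compound 1 to compound 2 (0.89 log units; beyond the scatter), read in reverse. That step was modest in size and in the direction of a weaker inhibitor when tert-butyl replaced 4-fluorophenyl; the return to a fluorophenyl group, now 2-fluorophenyl, is therefore expected to move the number down by a similar modest amount, roughly back to the level of compound 1. For compound 3 the estimated value in this assay is 1800 nM, with a range of 600 nM to 5400 nM, corresponding to an expected step of a 6.2-fold lower number from compound 2 to compound 3 (0.79 log units; beyond the scatter).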

Compound 3, inhibition constant: 1310 nM
Beside the measured number, compound 3's estimate is 1.4-fold (0.14 log units) above it; the range from low to high includes it.
By their numbers in this assay, from the lowest: compounds 3 and 1 (each within the scatter of the next); then compound 2.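

With 2-fluorophenyl in place of tert-butyl on a carbonyl carbon, this assay shows an 8.5-fold lower number from compound 2 to compound 3 (0.93 log units; beyond the scatter), so the step seen earlier from 4-fluorophenyl to tert-butyl now has a counterpart with a second fluorophenyl group: both fluorophenyl amides, compound 1 and compound 3, read lower than compound 2, and no compound shown goes against this. Changing 4-fluorophenyl to 2-fluorophenyl gives a 1.1-fold lower number from compound 1 to compound 3 (0.04 log units; within the scatter), so this assay does not separate these two placements of the fluorine, and the earlier pair could not show this. Nothing at hand explains either step.

On these data alone, how a plain phenyl, a cyclohexyl or a pyridine ring on this carbonyl carbon would read remains open, and with it whether the fluorine, the aromatic ring or neither accounts for the gap to compound 2. As far as these compounds go, all three compounds also share the rest of the core, so the effect of a longer chain or a carboxylic acid elsewhere on it, and whether any such change would bring a stronger inhibitor than compound 1 and compound 3, is also open.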